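Para-substituent variation on the aryl thiophene series

This account rests on a few compounds, and the source may have more. Where it says the series, first, only, none or still open, it means among the compounds named here.

Measured compounds in an assay on isolated protein for inhibition of cyclin-dependent kinase 2-associated protein 1 (Homo sapiens); on this read-out higher numbers stand for weaker inhibition and lower numbers for stronger inhibition:
compound 1 `NC(=O)Nc1sc(-c2ccc(C(=O)N3CCCCC3)cc2)cc1C(=O)N[C@H]1CCCNC1` gives 10800 nM
compound 2 `CN(C)C(=O)c1ccc(-c2cc(C(=O)N[C@H]3CCCNC3)c(NC(N)=O)s2)cc1` gives 3700 nM
compound 3 `CS(=O)(=O)c1ccc(-c2cc(C(=O)N[C@H]3CCCNC3)c(NC(N)=O)s2)cc1` gives 2200 nM

Compound 3 gives the lowest number of the three; compound 2 lies within the scatter of it, and only compound 1 stands beyond the scatter. The next compound, compound 4 `Cc1ccc(-c2cc(C(=O)N[C@H]3CCCNC3)c(NC(N)=O)s2)cc1`, carries methyl in place of methylsulfonyl on an aromatic carbon. The measured steps that approach this are those leading into compound 3, a 4.9-fold lower number from compound 1 to compound 3 (0.69 log units; beyond the scatter) and a 1.7-fold lower number from compound 2 to compound 3 (0.23 log units; within the scatter), both of which end with methylsulfonyl entering; neither shows methylsulfonyl leaving for a group without acceptors, so they bear on the present step only loosely. For compound 4 a modest movement toward a higher number in this assay is expected, a 2.0-fold higher number from compound 3 to compound 4 (0.31 log units; beyond the scatter). Compound 4 is therefore estimated at 4500 nM, with a range from 1500 nM to 13000 nM.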

Compound 4, half-maximal inhibitory concentration: 5500 nM
Compound 4: middle estimate off by 1.2-fold (0.09 log units), on the low side; low and high end bracket the measured number.
By their numbers in this assay, from the lowest: compounds 3, 2, 4 and 1 (each within the scatter of the next, the first and the last beyond it).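

In this assay, the exchange at this position, para to a large group, gives a step beyond the scatter: a 2.5-fold higher number from compound 3 to compound 4 (0.40 log units; beyond the scatter). Methyl, with no hydrogen-bond acceptors, is not separated from either amide, with a 1.5-fold higher number from compound 2 to compound 4 (0.17 log units; within the scatter) and a 2.0-fold lower number from compound 1 to compound 4 (0.29 log units; within the scatter) both within the scatter, so acceptors on this substituent are not required to fall in the range of compound 1 and compound 2. Nothing available explains why methylsulfonyl differs from methyl here.

Open, from the compounds shown here alone, is how an amine, a carboxylic acid or a longer chain on this carbon would read in this assay.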